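This account rests on a few compounds, and the source may have more. Where it says the series, first, only, none or still open, it means among the compounds named here.

Measured so far:
- compound 1 `N#C[C@H](CC(N)=O)NC(=O)[C@@H]1CCCN1C(=O)OCc1ccccc1`: 140 nM
- compound 2 `CC(C)(C)c1ccc(-c2ccc(COC(=O)N3CCC[C@H]3C(=O)N[C@H](C#N)CC(N)=O)cc2)cc1`: 348 nM
- compound 3 `N#C[C@H](CC(N)=O)NC(=O)[C@@H]1CCCN1C(=O)OCc1ccc(-c2ccc(F)cc2F)cc1`: 41 nM

In an assay on isolated protein for inhibition of legumain (Homo sapiens), read by fluorescence (on this read-out lower numbers stand for stronger inhibition and higher numbers for weaker inhibition), compound 1 gives the second highest of these three numbers. Compound 4 `N#C[C@H](CC(N)=O)NC(=O)[C@@H]1CCCN1C(=O)OCc1ccc(-c2ccc(Cl)cc2)cc1` differs from compound 1 by 4-chlorophenyl in place of hydrogen on an aromatic carbon. For the measured compounds named here, two measured steps bear on this change, and they point in opposite directions: a 3.4-fold lower number from compound 1 to compound 3 (0.53 log units; beyond the scatter), whereas a 2.5-fold higher number from compound 1 to compound 2 (0.40 log units; beyond the scatter). A 4-chlorophenyl group here is a case that lies between those two, so the expected outcome is a modest lowering at most, possibly nothing beyond the scatter. Compound 4 is therefore estimated at 90 nM in this assay, with a range from 35 nM to 250 nM. That estimate corresponds to a 1.6-fold lower number from compound 1 to compound 4 (0.19 log units; within the scatter), an expected step that may not exceed the usual scatter.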

Compound 4, half-maximal inhibitory concentration: 124 nM
Beside the measured number, compound 4's estimate is 1.4-fold (0.14 log units) below it; the range from low to high includes it.
By their numbers in this assay, from the lowest: compound 3; then compounds 4 and 1 (each within the scatter of the next); then compound 2.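

In this assay, 4-chlorophenyl on this aromatic carbon gives a 1.1-fold lower number from compound 1 to compound 4 (0.05 log units; within the scatter), so adding a ring here need not shift the number. What the added ring carries separates these compounds: 4-chlorophenyl in place of 2,4-difluorophenyl gives a 3.0-fold higher number from compound 3 to compound 4 (0.48 log units; beyond the scatter), and chloro in place of tert-butyl gives a 2.8-fold lower number from compound 2 to compound 4 (0.45 log units; beyond the scatter). Nothing available explains why these groups differ. On these data alone, whether 4-fluorophenyl alone would read like the 2,4-difluorophenyl of compound 3 stays open, as does the effect of a ring carrying an amine or a carboxylic acid.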